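This account rests on a few compounds, and the source may have more. Where it says the series, first, only, none or still open, it means among the compounds named here.

The measured compounds, each with its result in a functional assay (trachea) for antagonist activity, with Cavia porcellus as the target; a higher number here means a more potent compound, by a factor of ten per unit of this negative logarithm, a lower number a less potent compound:

compound 1, `CCCCC(CC)C(=O)Nc1ccc2ccn(Cc3ccc(C(=O)NS(=O)(=O)c4ccccc4C)cc3OC)c2c1`, gives 8.9
compound 2, `CCCCC(CC)C(=O)Nc1ccc2ccn(Cc3ccc(C(=O)NS(=O)(=O)c4ccc(OC)cc4)cc3OC)c2c1`, gives 7.4
compound 3, `CCCCC(CC)C(=O)Nc1ccc2ccn(Cc3ccc(C(=O)C(C#N)S(=O)(=O)c4ccccc4)cc3OC)c2c1`, gives 8.1

Compound 3 stands second highest of these three numbers: the step of a number 0.80 log units lower from compound 1 to compound 3 (beyond the scatter) separates it from the strongest of the set, while the step of a number 0.70 log units higher from compound 2 to compound 3 (beyond the scatter) places it above compound 2. All three share the same core and the same chain on the amide nitrogen; they differ only in the group attached to the carbonyl carbon that carries the sulfonyl-bearing unit.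

Compound 4, `CCCCC(CC)C(=O)Nc1ccc2ccn(Cc3ccc(C(=O)NS(=O)(=O)c4ccc(F)cc4)cc3OC)c2c1`, has not yet been measured. Relative to compound 3 the change is ((4-fluorophenyl)sulfonyl)amino in place of cyano(phenylsulfonyl)methyl on a carbonyl carbon.

Among the measured compounds shown here, two measured steps bear on this. Going back from compound 3 to a sulfonylamino group is the reverse of a number 0.80 log units lower from compound 1 to compound 3 (beyond the scatter) when the sulfonyl carries 2-methylphenyl, and the reverse of a number 0.70 log units higher from compound 2 to compound 3 (beyond the scatter) when it carries 4-methoxyphenyl. The ring substituent therefore matters, as the step of a number 1.50 log units lower from compound 1 to compound 2 (beyond the scatter) shows. For the measured compounds named here, a 4-fluorophenyl sulfonylamino group has no direct precedent here; a value between those two sulfonylamino compounds seems most plausible, which means roughly no step beyond the scatter is expected, a number 0.10 log units lower from compound 3 to compound 4 (within the scatter).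

For compound 4 the expected result in this assay is 8, with a range from 7.2 to 8.8.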

Compound 4, negative logarithm of the antagonist equilibrium constant: 7.7
Compound 4: the middle estimate sits 0.30 log units above what was measured; the range from low to high includes it.
By their numbers in this assay, from the lowest: compounds 2 and 4 (each within the scatter of the next); then compound 3; then compound 1.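

In this assay, fluoro in place of methoxy on an aromatic carbon gives a number 0.30 log units higher from compound 2 to compound 4 (within the scatter), so the 4-fluorophenyl and 4-methoxyphenyl groups on the sulfonyl sulfur cannot be told apart, whereas 4-fluorophenyl in place of 2-methylphenyl gives a number 1.20 log units lower from compound 1 to compound 4 (beyond the scatter). A large gap to compound 1 therefore appears with two different rings, those of compound 2 and compound 4, while replacing the whole unit on the carbonyl carbon gives a number 0.40 log units lower from compound 3 to compound 4 (beyond the scatter), although that exchange alters the ring as well as removing the nitrile and bringing in the amide hydrogen. Nothing measured here accounts for these differences.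

The compounds shown leave open whether compound 1 owes its number to the methyl group itself or to where it sits on the ring, a question that 4-methylphenyl and 2-fluorophenyl on the sulfonyl sulfur could help settle. They also leave open how an unsubstituted phenyl behaves on the sulfonylamino group, which would compare the two units on the carbonyl carbon with the same ring.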